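Side-chain hydroxylation on a tetrabromobenzotriazole series

This account rests on a few compounds, and the source may have more. Where it says the series, first, only, none or still open, it means among the compounds named here.

Measured compounds:
- compound 1, `C[C@@H](O)CCn1nc2c(Br)c(Br)c(Br)c(Br)c2n1`: 69%
- compound 2, `C[C@H](O)CCn1nc2c(Br)c(Br)c(Br)c(Br)c2n1`: 86%
- compound 3, `CC(O)CCn1nc2c(Br)c(Br)c(Br)c(Br)c2n1`: 89%

In a functional assay on CCRF-CEM cells (Homo sapiens) for antiproliferative activity, read by MTT assay, with a stated time of 24 h, tested at 50 uM (a lower number here means a stronger effect, a higher number a weaker effect of the compound at the concentration tested), compound 3 gives 89%, the highest of the three numbers and thus the weakest effect shown. Compound 2 sits close to it, and the step of a number 3 percentage points higher from compound 2 to compound 3 (within the scatter) lies within the scatter. Compound 1 stands apart: the step of a number 20 percentage points higher from compound 1 to compound 3 (beyond the scatter) and the step of a number 17 percentage points higher from compound 1 to compound 2 (beyond the scatter) are both modest but beyond the scatter, and both come down to configuration alone, since (the fact that compounds 1 and 2 differ only in the configuration as drawn), the fact that one of compounds 1 and 3 is drawn with a defined configuration and the other without, at the place where they differ and the fact that one of compounds 2 and 3 is drawn with a defined configuration and the other without, at the place where they differ each concern a single stereocentre at a saturated chain carbon.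

Compound 4, `OCC(O)Cn1nc2c(Br)c(Br)c(Br)c(Br)c2n1`, differs from compound 3 by 1,2-dihydroxyethyl in place of 2-hydroxypropyl on a saturated chain carbon bound to an aromatic nitrogen. Among the compounds with values here, none of the measured steps touches this kind of change; all three alter configuration, not the chain itself, so they give no direction for it. The estimate for compound 4 therefore rests on compound 3 alone, and compound 4 is expected to give 85% in this assay, with a range from 62% to 100%. The step of a number 4 percentage points lower from compound 3 to compound 4 (within the scatter) is thus estimated as none beyond the scatter, with wide uncertainty.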

Compound 4, a percentage reported as activity, at one concentration (the size of the read-out at that concentration, not a potency): 47%
The estimate for compound 4 lay 38 percentage points above the measured number, outside the stated range (below it).
By their numbers in this assay, from the lowest: compound 4; then compound 1; then compounds 2 and 3 (each within the scatter of the next).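

In this assay the chain itself proves to matter at this position, and not only its configuration: 1,2-dihydroxyethyl in place of 2-hydroxypropyl on a saturated chain carbon bound to an aromatic nitrogen gives a number 42 percentage points lower from compound 3 to compound 4 (beyond the scatter) and a number 39 percentage points lower from compound 2 to compound 4 (beyond the scatter), both large, and a number 22 percentage points lower from compound 1 to compound 4 (beyond the scatter), which is modest. With all three steps beyond the scatter, compound 4 shows the strongest effect of the four compounds at the concentration tested. Nothing at hand explains why this change has such an effect.

The compounds shown leave open whether configuration at the chain carbon of compound 4 matters as it does between compound 1 and compound 2. They also leave open whether an amine, a carboxylic acid or a longer chain at this place would act like 1,2-dihydroxyethyl.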